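The compounds below may be only part of what the source reports. "The series", "measured", "known", "first", "only" and "open" are said of these compounds alone.

Measured so far in a functional assay on L1210 cells (Mus musculus), with a stated time of 12 days; on this read-out higher numbers stand for higher potency (the scale is a negative logarithm) and lower numbers for lower potency:
- compound 1 `CCCC1=C(N2CC2)C(=O)C(C(COC(N)=O)OC)=C(N2CC2)C1=O`: 5.07
- compound 2 `CCC1=C(N2CC2)C(=O)C(C(COC(N)=O)OC)=C(N2CC2)C1=O`: 5.22
- compound 3 `CCOC(COC(N)=O)C1=C(N2CC2)C(=O)C(CC)=C(N2CC2)C1=O`: 5.24

Compound 2 gives the second highest of the three numbers; compound 3 sits nearest, and the step of a number 0.02 log units higher from compound 2 to compound 3 (within the scatter) lies within the scatter, while compound 1 sits furthest, the step of a number 0.15 log units higher from compound 1 to compound 2 (within the scatter) also within the scatter. Within the data shown here, all three numbers therefore sit together, and no compound can be set apart.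

Compound 4 `CCC1=C(N2CC2)C(=O)C(CC)=C(N2CC2)C1=O` is not yet measured. It differs from compound 2 by a group of 2 heavy atoms (2 carbon; no ring) in place of a group of 8 heavy atoms (4 carbon, 1 nitrogen, 3 oxygen; no ring), on a double-bonded ring carbon. The change sits on a double-bonded ring carbon of a six-membered non-aromatic ring of carbon only, three ring bonds from the ring atom that bears an ethyl group.

Both measured steps bear on this only loosely: each alters a single methyl on the chain that is now removed altogether, and each stayed within the scatter. Among the measured compounds shown here, no step removes the whole group, so the expectation rests on the flatness seen so far. A step of a number 0.12 log units lower from compound 2 to compound 4 (within the scatter) is expected, with no clear direction beyond the scatter. Compound 4 is estimated at 5.1, expected range 4.4 to 5.8.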

Compound 4, logarithm of the reciprocal of the active concentration, log(1/C): 5.09
Compound 4: the middle estimate sits 0.01 log units above what was measured, and the stated range covers the measured number.
By their numbers in this assay, from the lowest: compounds 1, 4, 2 and 3 (each within the scatter of the next).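

Replacing the group of 8 heavy atoms on this double-bonded ring carbon with ethyl gives, in this assay, a number 0.13 log units lower from compound 2 to compound 4 (within the scatter). The earlier steps shown here altered only a single methyl on that chain, whereas this one removes the whole group, including its 1 hydrogen-bond donor and 3 hydrogen-bond acceptors, and the read-out still stays within the scatter, so for this pair the full group is not required to hold the number at this level. Nothing available on these compounds accounts for this flat result.

The compounds shown leave open whether an amine, a carboxylic acid or a plain hydrogen on this ring carbon would move the number beyond the scatter. They also leave open whether the same tolerance would hold with a longer chain in place of the ethyl group three ring bonds away.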